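A few compounds are considered here, and "the series" means these few. Any claim that something is new, unique, unknown or untested is made for them only; others in the source may bear on it.

Measured compounds:
Compound 1 `COc1cc(OC)c(/C=C/S(=O)(=O)Cc2ccc(OC)c(N)c2)c(OC)c1`: < 10 nM
Compound 2 `COc1ccc(CS(=O)(=O)/C=C/c2c(OC)cccc2OC)cc1N`: 40 nM

Both were tested in a functional assay on MCF7 cells (Homo sapiens) for cytotoxicity, read by MTT assay, with a stated time of 72 h; a higher number here means a weaker inhibitor of growth, a lower number a stronger inhibitor of growth. For compound 1 the result is a limit of the assay, (the limit of < 10 nM in this assay, at which 1 of the 2 values shown sits), so its exact number is not known. Compound 2 gives 40 nM, and the step of an at least 4.0-fold higher number from compound 1 to compound 2 (0.60 log units; beyond the scatter) came with a single change, hydrogen in place of methoxy on an aromatic carbon. Compound 3 `COc1cc(OC)c(/C=C/S(=O)(=O)Cc2ccc(OC)c(NC(C)=O)c2)c(OC)c1` has not yet been measured. It differs from compound 1 by acetyl in place of hydrogen on a nitrogen on an aromatic ring. Among the compounds with values here, no measured step involves a change on that nitrogen, so the step from compound 1 to compound 2 does not bear on it directly; it shows only that one small change can shift the number beyond the scatter. Because the limit of < 10 nM in this assay, at which 1 of the 2 values shown sits, leaves the starting point open, the step can be judged only loosely, and a modest weakening is expected, giving an at least 3.0-fold higher number from compound 1 to compound 3 (0.47 log units; beyond the scatter). Compound 3 is expected to give 30 nM, with a likely range from 5 nM to 200 nM.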

Compound 3, concentration for 50% growth inhibition: 350 nM
Beside the measured number, compound 3's estimate is 12-fold (1.07 log units) below it; measured number outside the range, above it.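

Turning amino into acetamido gives an at least 35-fold higher number from compound 1 to compound 3 (1.54 log units; beyond the scatter) in this assay and so shows for the first time that this nitrogen on the aromatic ring is sensitive to change. In this pair, keeping the hydrogen on the nitrogen goes with much stronger growth inhibition than carrying acetyl there, so the position cannot be treated as free for substitution on the core of compound 1. Going by these compounds, the exact size of the step remains unknown, and only its lower bound can be read, because the value for compound 1 is a limit: the limit of < 10 nM in this assay, at which 1 of the 3 values shown sits.

On these data alone, only hydrogen and acetyl appear on this nitrogen, so it remains open how a methyl group or a longer acyl chain such as propanoyl would fare. As far as these compounds go, whether acetyl would cost as much on compound 2 also remains open.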